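Pyrrolidine nitrogen capping in a fused bicyclic anilino series

This account rests on a few compounds, and the source may have more. Where it says the series, first, only, none or still open, it means among the compounds named here.

Measured compounds:
- compound 1 `CN1CCN(c2ccc(Nc3ncc4nc(Nc5ccc(F)cc5)n([C@@H]5CCN(C(=O)CO)C5)c4n3)cc2)CC1`, "not determined" (no result reported) in a functional assay on A549 cells (Homo sapiens) for antiproliferative activity, read by MTT assay, with a stated time of 72 h; on this read-out higher numbers stand for weaker inhibition and lower numbers for stronger inhibition
- compound 2 `CN1CCN(c2ccc(Nc3ncc4nc(Nc5ccc(F)cc5)n([C@@H]5CCN(S(=O)(=O)C6CC6)C5)c4n3)cc2)CC1`, > 10000 nM in this assay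
- compound 3 `CN1CCN(c2ccc(Nc3ncc4nc(Nc5ccc(F)cc5)n([C@@H]5CCN(C(=O)OC(C)(C)C)C5)c4n3)cc2)CC1`, "not determined" (no result reported) in this assay

Compound 3 has no number in this assay; of the other two entries, one is a limit and one has no result. The limit belongs to compound 2, which in this assay gives only > 10000 nM, not a number; see (the limit of > 10000 nM in this assay, at which 1 of the 3 values shown sits).

Compound 4 `CN1CCN(c2ccc(Nc3ncc4nc(Nc5ccc(F)cc5)n([C@H]5CCN(S(=O)(=O)C6CC6)C5)c4n3)cc2)CC1` follows from compound 3 by 1-(cyclopropylsulfonyl)pyrrolidin-3-yl in place of 1-(tert-butoxycarbonyl)pyrrolidin-3-yl on an aromatic nitrogen. Compound 4 carries the same capping group as compound 2 and differs from it only at the defined stereocentre. Among the compounds with values here, with no steps between measured compounds to draw on, no direction beyond the scatter can be stated. Given that compound 2 gives > 10000 nM, compound 4 is expected to sit near or at the limit as well, estimated at 10000 nM, within 2000 nM to 50000 nM.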

Compound 4, half-maximal inhibitory concentration: 150 nM
Estimate against measurement, compound 4: 67-fold (1.82 log units) above, and the stated range ends above it.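

In this assay, changing only the configuration at the saturated ring carbon of the 1-(cyclopropylsulfonyl)pyrrolidin-3-yl group gives an at least 66-fold lower number from compound 2 to compound 4 (1.82 log units; beyond the scatter). The entry for compound 2, > 10000 nM, is a limit and not a number. At this position the stereocentre alone therefore separates a measurable result from a limit: the fact that compounds 2 and 4 differ only in the configuration as drawn

On these data alone, compounds 1 and 3 have no result, so steps involving them cannot be read and the contribution of the capping group stays open. As far as these compounds go, whether an acetyl group or a free amine on the pyrrolidine nitrogen would hold the level of compound 4 also remains open.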